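Dichlorophenyl Variant of a Low-Cytotoxicity Thiazole Series

A few compounds are considered here, and "the series" means these few. Any claim that something is new, unique, unknown or untested is made for them only; others in the source may bear on it.

Measured compounds:
compound 1 `CCOC(=O)c1sc(-c2ccccc2)nc1N1CCC(NCc2ccccc2)CC1`, 11.7%
compound 2 `CCOC(=O)c1sc(-c2ccccn2)nc1N1CCC(NCc2ccccc2)CC1`, 14.6%
compound 3 `CCOC(=O)c1sc(-c2ccccn2)nc1N1CCC(NCc2ccc(OCc3ccccc3)cc2)CC1`, 12.8%

All three compounds were tested in an ADME assay on RAW264.7 cells (Mus musculus) for cytotoxicity, read by MTT assay, with a stated time of 72 h, tested at 50 uM (on this read-out higher numbers stand for more inhibition at the one concentration tested (going by the name of the read-out) and lower numbers for less inhibition), and all three sit low. Compound 2 has the highest of the three numbers, yet its separation from compound 3 and from compound 1 lies within the scatter, so no order among them can be claimed.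

Compound 4 `CCOC(=O)c1sc(-c2ccccn2)nc1N1CCC(NCc2ccc(Cl)c(Cl)c2)CC1` has not yet been measured. It differs from compound 2 in one place: 3,4-dichlorophenyl in place of phenyl on a saturated chain carbon bound to an amine nitrogen. The step that bears most directly on this change is the one that also alters the phenyl bound to the amine-side carbon, namely a number 1.8 percentage points lower from compound 2 to compound 3 (within the scatter). The other step, a number 2.9 percentage points higher from compound 1 to compound 2 (within the scatter), touches a different part of the molecule but likewise stayed within the scatter. On this basis the estimated step from compound 2 to compound 4 in this assay is a number 1.4 percentage points higher from compound 2 to compound 4 (within the scatter), that is, none beyond the scatter. Compound 4 is therefore expected to give about 16%, within a range of 6% to 28%.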

Compound 4, a percentage reported as inhibition, at one concentration (the size of the read-out at that concentration, not a potency): 30.1%
Compound 4: the middle estimate sits 14.1 percentage points below what was measured; the measured number lies above the stated range.
By their numbers in this assay, from the lowest: compounds 1, 3 and 2 (each within the scatter of the next); then compound 4.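

In this assay the change to 3,4-dichlorophenyl on a saturated chain carbon bound to an amine nitrogen gives a number 15.5 percentage points higher from compound 2 to compound 4 (beyond the scatter) and is the only step shown to lie beyond the scatter. This shows that the read-out can respond to a change in the benzylamino part of the molecule, which the benzyloxy group did not show with a number 1.8 percentage points lower from compound 2 to compound 3 (within the scatter) in this assay. Nothing measured here accounts for the difference between these two changes.

The compounds shown leave open whether a single chlorine on the benzyl group would give a similar step, or whether fluorine or methyl in place of the chlorines would do so. They also leave open whether 3,4-dichlorobenzyl would give a step of similar size with phenyl in place of pyridin-2-yl.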